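The source may hold more compounds than are shown below. What is called first, only, known or untested is meant among the compounds shown, and "the series" means these compounds.

Three compounds built on one shared core were examined in an ADME assay on L929 cells (Mus musculus) for cytotoxicity, read by resazurin assay, with a stated time of 72 h; a lower number here means a stronger inhibitor, a higher number a weaker inhibitor. Compound 1 `O=C(c1ccn(-c2ccc3c(c2)B(O)OC3)c1)c1ccc(Cl)cc1Cl` gives a result that is only a limit of the assay, > 10 ug/mL. Compound 2 `O=C(c1ccn(-c2ccc3c(c2)B(O)OC3)c1)c1ccccc1Cl` likewise returns a limit, > 10 ug/mL. Compound 3 `O=C(c1ccc(Cl)cc1)c1ccn(-c2ccc3c(c2)B(O)OC3)c1` also stands at a limit, > 10 ug/mL. Because every value so far sits at the limit of > 10 ug/mL in this assay, at which 3 of the 3 values shown sit, none of the steps among these compounds can be read: a step that the two limits leave unreadable from compound 1 to compound 2, a step that the two limits leave unreadable from compound 1 to compound 3 and a step that the two limits leave unreadable from compound 2 to compound 3 all remain unreadable in size.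

Compound 4 `O=C(c1cccc(Cl)c1)c1ccn(-c2ccc3c(c2)B(O)OC3)c1` has not yet been measured; it differs from compound 3 by 3-chlorophenyl in place of 4-chlorophenyl on a carbonyl carbon. Among the compounds with values here, the one measured step touching the same carbonyl carbon, a step that the two limits leave unreadable from compound 2 to compound 3, offers no readable size, so no direction can be drawn from it, and the expectation is of no step beyond the scatter. For compound 4 the expected step is a step that the limit leaves unreadable from compound 3 to compound 4, and the estimated value is 15 ug/mL, with a range from 8 ug/mL to 40 ug/mL, most likely reported once more only as a limit.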

Compound 4, half-maximal inhibitory concentration: > 10 ug/mL
Compound 4: only a limit was reported; the forecaster's own chance of this, stated with the estimate: 75%; the middle value is on the limit's open side.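

Compound 4 too gives only a limit in this assay, so none of its steps to compound 1, compound 2 or compound 3 can be read: the limit of > 10 ug/mL in this assay, at which 4 of the 4 values shown sit.

The compounds shown leave open whether exchanging these groups on the carbonyl carbon changes the result in this assay at all.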